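This account rests on a few compounds, and the source may have more. Where it says the series, first, only, none or still open, it means among the compounds named here.

Of the compounds shown here, two sharing one core have been measured. Compound 1, `Nc1scc(-c2ccc(F)cc2)c1C(=O)c1ccc(Cl)cc1`, gives 61% in a functional assay on CHO cells for agonist activity at adenosine receptor A1 (Homo sapiens), read by fluorescence and ERK phosphorylation, with stated times of 30 min and 1.5 h, tested at 10 uM; a lower number here means a weaker effect, a higher number a stronger effect of the compound at the concentration tested. Compound 2, `Nc1scc(-c2ccc(I)cc2)c1C(=O)c1ccc(Cl)cc1`, gives 61% in this assay, so compound 2 stands level with compound 1 at the digits shown. Going by the values given here, the only measured step, no change at the digits printed from compound 1 to compound 2 (within the scatter), swaps one halogen for another on the aromatic ring and stays within the scatter.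

Compound 3, `Nc1scc(-c2ccc([N+](=O)[O-])cc2)c1C(=O)c1ccc(Cl)cc1`, has not been measured. It differs from compound 2 as follows: nitro in place of iodo on an aromatic carbon. Among the compounds with values here, the measured step bears only loosely on this change, since it replaced one halogen with another rather than introducing a nitro group; no measured step exchanges a halogen for a nitro group. With that single step showing no change, the expected step of a number 3 percentage points lower from compound 2 to compound 3 (within the scatter) is small, without a clear direction beyond the scatter. The estimate for compound 3 in this assay is 58%, within a range from 38% to 75%.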

Compound 3, a percentage reported as activity, at one concentration (the size of the read-out at that concentration, not a potency): 52%
Beside the measured number, compound 3's estimate is 6 percentage points above it; low and high end bracket the measured number.
By their numbers in this assay, from the lowest: compounds 3, 1 and 2 (each within the scatter of the next).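

Until now only halogens had sat on this aromatic carbon, para to a large group. Nitro, with 3 heavy atoms and 2 hydrogen-bond acceptors where iodo has 1 heavy atom and no acceptor, gives a number 9 percentage points lower from compound 2 to compound 3 (within the scatter) in this assay, and the comparison with the fluoro compound gives the same picture, a number 9 percentage points lower from compound 1 to compound 3 (within the scatter), so across these three compounds a group other than a halogen at this place produces no step beyond the scatter. Nothing is available that would explain why the three compounds sit so close together.

From the compounds shown here alone, whether an amine, a carboxylic acid or a longer chain on this carbon would stay within the same range remains open. Going by these compounds, these numbers also come from a single concentration, so they show only the size of the effect at that concentration, and whether any compound would give a stronger or weaker effect at other concentrations is unknown.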